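The compounds below may be only part of what the source reports. "The series", "measured", "known", "first", "only" and "open" are said of these compounds alone.

Measured compounds, with their values in a functional assay on KYSE-70 cells for antiproliferative activity against KYSE-70 cell line (Homo sapiens), read by MTT assay, with a stated time of 72 h; on this read-out lower numbers stand for stronger inhibition and higher numbers for weaker inhibition:
- compound 1, `O=C(Nc1cccc(F)c1)c1cc(=O)[nH]c2cc(F)ccc12`: > 20000 nM, a limit of the assay, not a number
- compound 2, `O=C(Nc1cccc(F)c1)c1cc(=O)[nH]c2cc(-c3ccccc3F)ccc12`: > 20000 nM, likewise a limit of the assay

Compound 2 stands at the limit only; its value is a limit, not a number, so no number of its own is known for it. For the measured compounds named here, the one step among the measured compounds, a step that the two limits leave unreadable from compound 1 to compound 2, runs between two limits and its size cannot be read. Going by the values given here, the only evidence is the limit of > 20000 nM in this assay, at which 2 of the 2 values shown sit.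

Compound 3, `O=C(Nc1cccc(F)c1)c1cc(=O)[nH]c2cc(-c3ccc(F)nc3)ccc12`, differs from compound 2 as follows: 6-fluoropyridin-3-yl in place of 2-fluorophenyl on an aromatic carbon. Among the compounds with values here, the step that bears on it, from compound 1 to compound 2, is unreadable, so it gives no measure of how far a change at this aromatic carbon moves the read-out; it shows only that the larger group did not bring the value into the readable range.

The expectation for compound 3 in this assay is therefore that it again sits at or beyond the limit, with the step that the limit leaves unreadable from compound 2 to compound 3 expected to be small. Compound 3 is estimated at 30000 nM, within 12000 nM to 80000 nM.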

Compound 3, half-maximal inhibitory concentration: > 20000 nM
Compound 3 ended at the assay's limit (the forecaster's own chance of this, stated with the estimate: 85%); the middle value is on the limit's open side.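

In this assay compound 3 gives > 20000 nM, a limit of the assay and not a number. For the compounds shown here, compound 1 and compound 2 also stand at limits, so no step among compound 1, compound 2 and compound 3 can be read. The compounds shown leave open whether any group at this aromatic carbon brings the shared core into the readable range: the limit of > 20000 nM in this assay, at which 3 of the 3 values shown sit.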